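Chloromethyl for vinyl on a weak compound

The source may hold more compounds than are shown below. What is called first, only, known or untested is meant among the compounds shown, and "the series" means these compounds.

- compound 1 `O=C(CCl)N1CCCC(n2nc(-c3ccc(Oc4ccccc4)cc3)cc2CO)C1` with 400 nM
- compound 2 `C=CC(=O)N1CCCC(n2nc(-c3ccc(Oc4ccccc4)cc3)cc2C(=O)OCC)C1` with 13800 nM

Both numbers come from a functional assay on Rec1 cells (Homo sapiens) for inhibition, read by luminescence and CellTiter-Glo, with a stated time of 72 h (on this read-out higher numbers stand for weaker inhibition and lower numbers for stronger inhibition), and can be compared directly. Compound 2 has the higher of the two numbers, so it is the weaker inhibitor of this pair, and its gap to compound 1 lies beyond the usual scatter of repeated measurements.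

Compound 3 `CCOC(=O)c1cc(-c2ccc(Oc3ccccc3)cc2)nn1C1CCCN(C(=O)CCl)C1` is compound 2 with a single change, chloromethyl in place of vinyl on a carbonyl carbon. Within the data shown here, no measured pair shows this change alone. Among the measured compounds shown here, the only guide is compound 1, which also carries chloromethyl on a carbonyl carbon. In this assay compound 1 gives 400 nM but it also differs from compound 3 elsewhere on the core, so only part of its gap to compound 2 is expected to carry over. A move towards stronger inhibition is therefore expected, estimated as a 5.5-fold lower number from compound 2 to compound 3 (0.74 log units; beyond the scatter) and beyond the scatter. Compound 3 is expected to give about 2500 nM (estimated range 500 nM to 10000 nM).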

Compound 3, half-maximal inhibitory concentration: 400 nM
Compound 3: the middle estimate sits 6.3-fold (0.80 log units) above what was measured, outside the stated range (below it).
By their numbers in this assay, from the lowest: compounds 1 and 3 (each within the scatter of the next); then compound 2.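

In this assay, putting chloromethyl in place of vinyl on the carbonyl carbon gives a 35-fold lower number from compound 2 to compound 3 (1.54 log units; beyond the scatter) while the rest of the molecule stays the same, so this position has a large effect on the read-out. The ethoxycarbonyl group seen on the weak vinyl compound does not by itself hold the number high, as ethoxycarbonyl in place of hydroxymethyl on the aromatic carbon gives no change at the digits printed from compound 1 to compound 3 (within the scatter) when chloromethyl is present. The numbers show the size of the change at the carbonyl carbon, but nothing shown here explains why it is so large.

A compound pairing vinyl with hydroxymethyl would be needed to tell whether the two positions act independently, or whether the group on the aromatic carbon matters only when vinyl is present. Also open, on these data alone, is how this assay would respond to a bromomethyl group or a longer chain on the carbonyl carbon, or to a carboxylic acid or an amine in place of ethoxycarbonyl on the aromatic carbon.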